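A few compounds are considered here, and "the series" means these few. Any claim that something is new, unique, unknown or untested is made for them only; others in the source may bear on it.

Measured compounds:
compound 1 `Cc1noc(C)c1-c1cnc(N)c(Oc2ccc(C(=O)NC3CCCC3)cc2)n1` — 25200 nM
compound 2 `Cc1noc(C)c1-c1cnc(N)c(Oc2ccc(C(=O)Nc3ccccc3)cc2)n1` — 5740 nM
compound 3 `Cc1noc(C)c1-c1cnc(N)c(Oc2ccc(C(=O)Nc3cccc(Cl)n3)cc2)n1` — 39300 nM

In a functional assay on LoVo cells (Homo sapiens) for inhibition, read by MTT assay, with a stated time of 72 h (on this read-out lower numbers stand for stronger inhibition and higher numbers for weaker inhibition), compound 1 stands second highest of the three numbers; its nearest neighbour is compound 3, and the gap to it lies within the scatter, while compound 2 is the furthest, giving a clearly lower number. The step to the unmeasured compound 4 `Cc1noc(C)c1-c1cnc(N)c(Oc2ccc(C(=O)Nc3cc(Cl)ccn3)cc2)n1` is 4-chloropyridin-2-yl in place of cyclopentyl on an amide-type nitrogen. Among the compounds with values here, two measured steps bear on it. The closest is a 1.6-fold higher number from compound 1 to compound 3 (0.19 log units; within the scatter), where a chloropyridinyl group also replaced the cyclopentyl and the number hardly moved. The other is a 4.4-fold lower number from compound 1 to compound 2 (0.64 log units; beyond the scatter), where an aromatic phenyl ring in place of cyclopentyl gave a modestly lower number. The 4-chloropyridin-2-yl group of compound 4 is an aromatic ring like both, but carries the chlorine and ring nitrogen like compound 3, so the expectation is for a step that is at most modest, and most likely within the scatter, in this assay. Compound 4 is therefore estimated at 20000 nM, with a range from 6000 nM to 50000 nM, which would mean a step of a 1.3-fold lower number from compound 1 to compound 4 (0.10 log units; within the scatter).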

Compound 4, half-maximal inhibitory concentration: > 100000 nM
Compound 4 ended at the assay's limit; the forecaster's own chance of this, stated with the estimate: 5%; at least 5.0-fold (0.69 log units) between middle value and limit.
By their numbers in this assay, from the lowest: compound 2; then compounds 1 and 3 (each within the scatter of the next). At a limit, above all of these: compound 4.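

In this assay compound 4 gives only a limit of the assay and not a number: the limit of > 100000 nM in this assay, at which 1 of the 4 values shown sits. The two chloropyridinyl groups are not interchangeable on the amide-type nitrogen, as 4-chloropyridin-2-yl in place of 6-chloropyridin-2-yl gives an at least 2.5-fold higher number from compound 3 to compound 4 (0.40 log units; beyond the scatter). Against cyclopentyl the new group gives an at least 3.9-fold higher number from compound 1 to compound 4 (0.59 log units; beyond the scatter), and against phenyl it gives an at least 17-fold higher number from compound 2 to compound 4 (1.24 log units; beyond the scatter), so among these compounds an aromatic ring on this nitrogen does not by itself bring the lower number seen with compound 2.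

With only these two chloropyridinyl groups, the part played by the chlorine cannot be separated from that of the ring nitrogen. From the compounds shown here alone, whether a plain pyridin-2-yl, a 4-methylpyridin-2-yl or a 3-chlorophenyl on the same nitrogen would read closer to compound 2 or to compound 4 remains open.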